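Replacing the acid-bearing benzimidazole with a methyl ester of a methylbenzoate

The compounds below may be only part of what the source reports. "The series", "measured", "known", "first", "only" and "open" are said of these compounds alone.

Measured compounds:
compound 1 `O=C(O)c1ccc2nc(CN3CCC[C@H](O[C@H](CO)c4cc(Cl)cc(Cl)c4)[C@@H]3c3ccccc3)[nH]c2c1` — 43000 nM
compound 2 `Cc1cc(C(=O)O)ccc1CN1CCC[C@H](O[C@H](CO)c2cc(Cl)cc(Cl)c2)[C@@H]1c1ccccc1F` — "nd" (no result reported)
compound 3 `Cc1cc(C(=O)O)ccc1CN1C(=O)CC[C@H](OCc2cc(Cl)cc(Cl)c2)[C@@H]1c1ccccc1` — > 200000 nM

In an assay on isolated protein for activation of cGMP-dependent protein kinase 1 (Homo sapiens), read by ADP-Glo, with stated times of 30 min and 2 h (on this read-out lower numbers stand for an effect already at smaller amounts and higher numbers for an effect only at larger amounts of compound), compound 1 gives 43000 nM, the only single number among the three compounds shown. Compound 2 has no result in this assay. For compound 3 the value is a limit of this assay, > 200000 nM, as noted in the limit of > 200000 nM in this assay, at which 1 of the 3 values shown sits. Among the measured compounds shown here, no pair of measured compounds differs in just one place, so no measured step is available.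

Compound 4 `COC(=O)c1ccc(CN2CCC[C@H](O[C@H](CO)c3cc(Cl)cc(Cl)c3)[C@@H]2c2ccccc2)c(C)c1` differs from compound 1 at the saturated chain carbon bound to the amine nitrogen in the ring: a group of 11 heavy atoms (9 carbon, 2 oxygen; one six-membered aromatic ring of carbon only) in place of a group of 12 heavy atoms (8 carbon, 2 nitrogen, 2 oxygen; one five-membered aromatic ring with 2 hetero atoms, one six-membered aromatic ring of carbon only), on a saturated chain carbon bound to an amine nitrogen in a ring. For the measured compounds named here, with compound 1 as the only anchor and no measured step to guide the direction, the author expects the change to move the value toward higher concentrations, by more than the usual scatter, so that a 2.3-fold higher number from compound 1 to compound 4 (0.37 log units; beyond the scatter) is the estimated step. Compound 4 is therefore estimated at 100000 nM, with a range from 30000 nM to 300000 nM, and a real chance that this assay reports only a limit.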

Compound 4, half-maximal effective concentration: > 200000 nM
Compound 4 ended at the assay's limit; the forecaster's own chance of this, stated with the estimate: 40%; middle value at least 2.0-fold (0.30 log units) away from the limit.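

In this assay, compound 4 gives > 200000 nM, which is a limit of the assay and not a number. Even so, this replacement on a saturated chain carbon bound to an amine nitrogen in a ring gives the first readable step at this position: an at least 4.6-fold higher number from compound 1 to compound 4 (0.66 log units; beyond the scatter). The entering group has 0 hydrogen-bond donors where the leaving group has 2, and the result puts a second compound at the limit: the limit of > 200000 nM in this assay, at which 2 of the 4 values shown sit.

The compounds shown cannot separate the loss of the five-membered aromatic ring from the change of the carboxylic acid to a methyl ester, since both change in this one step. Going by these compounds, it remains open whether a methylbenzoic acid, with a free carboxylic acid in place of the ester, would give a measurable value on the core of compound 4.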